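Amide aryl variation on the shared core: expectations for compound 4

This account rests on a few compounds, and the source may have more. Where it says the series, first, only, none or still open, it means among the compounds named here.

The series keeps the core of compound 1 `COC(=O)c1scc(-c2ccc(NC(=O)c3cc(I)ccc3F)cc2)c1OC` and varies the aryl group on the amide carbonyl. In a functional assay on HeLa cells (Homo sapiens) for antiproliferative activity, read by MTT assay, with a stated time of 24 h (on this read-out lower numbers stand for stronger inhibition and higher numbers for weaker inhibition), compound 1 itself gives "not determined" (no result reported), so no result is available for it. Two measured members of the series set the scale: compound 2 `COC(=O)c1scc(-c2ccc(NC(=O)c3ccc4ccccc4c3)cc2)c1OC` gives 18200 nM in this assay, and compound 3 `COC(=O)c1scc(-c2ccc(NC(=O)c3ccc(C(F)(F)F)cc3Br)cc2)c1OC` gives 16200 nM in this assay; these two values sit within the usual scatter of each other, so no order between them is claimed. Compound 4 `COC(=O)c1scc(-c2ccc(NC(=O)c3ccc(C(F)(F)F)cc3)cc2)c1OC` is the next member to be measured. Its change from compound 1 is 4-(trifluoromethyl)phenyl in place of 2-fluoro-5-iodophenyl on a carbonyl carbon. Going by the values given here, no measured step separates compound 1 and compound 4, and compound 1 has no number of its own, so no step size can be taken from the data. What is expected is that compound 4 falls where compound 2 and compound 3 already lie, with no shift beyond the scatter anticipated in this assay. Compound 4 is therefore estimated at 17000 nM, in the range 6000 nM to 45000 nM.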

Compound 4, half-maximal inhibitory concentration: 14400 nM
For compound 4 the middle estimate is 1.2-fold (0.07 log units) above the measured one, and the stated range covers the measured number.
By their numbers in this assay, from the lowest: compounds 4, 3 and 2 (each within the scatter of the next).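

In this assay there is a 1.1-fold lower number from compound 3 to compound 4 (0.05 log units; within the scatter) with hydrogen in place of bromo on an aromatic carbon, so this bromo group makes no difference that can be read on the 4-(trifluoromethyl)phenyl amide. Replacing naphthalen-2-yl with 4-(trifluoromethyl)phenyl on a carbonyl carbon gives a 1.3-fold lower number from compound 2 to compound 4 (0.10 log units; within the scatter) and likewise stays within the scatter, so among compounds 2, 3 and 4 neither change separates the aryl groups at this position. No supporting measurement is available to explain this flat result.

Steps involving compound 1 cannot be read, which leaves the 2-fluoro-5-iodophenyl group unplaced against the others. From the compounds shown here alone, it remains open whether an aryl group carrying an amine or a carboxylic acid at this position would move the number beyond the scatter.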